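The source may report more compounds than this note shows. Statements on the series, on what has been measured and on what is new or still open speak of the compounds shown alone.

In a functional assay on A-375 cells (Homo sapiens) for antiproliferative activity, read by MTT assay, with a stated time of 24 h (on this read-out lower numbers stand for stronger inhibition and higher numbers for weaker inhibition), compound 1 `COc1cc(OC)c(-c2coc3cc(OCc4ccc(F)cc4)ccc3c2=O)cc1OC` gives 1720 nM, compound 2 `COc1cc(OC)c(-c2coc3cc(OCc4ccc(Br)cc4)ccc3c2=O)cc1OC` gives 1000 nM and compound 3 `COc1cc(OC)c(-c2coc3cc(OCc4ccccc4Cl)ccc3c2=O)cc1OC` gives 2020 nM. Compound 3 thus holds the highest of the three numbers, with a 1.2-fold higher number from compound 1 to compound 3 (0.07 log units; within the scatter) inside the scatter and a 2.0-fold higher number from compound 2 to compound 3 (0.31 log units; beyond the scatter) modestly beyond it. Compound 4 `COc1cc(OC)c(-c2coc3cc(OCc4ccc(C(F)(F)F)cc4)ccc3c2=O)cc1OC` differs from compound 3 by 4-(trifluoromethyl)phenyl in place of 2-chlorophenyl on a saturated chain carbon bound to an oxygen on an aromatic ring, placing 4-(trifluoromethyl)phenyl where 2-chlorophenyl stood. Among the measured compounds shown here, the steps that bear on this change are those two and a 1.7-fold lower number from compound 1 to compound 2 (0.24 log units; within the scatter), which also lies within the scatter. All are small, so only a small shift towards a lower number is expected, not one beyond the scatter. The expected step is a 1.4-fold lower number from compound 3 to compound 4 (0.16 log units; within the scatter). Compound 4 is estimated at 1400 nM, with an expected range of 700 nM to 2800 nM.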

Compound 4, half-maximal inhibitory concentration: 2280 nM
The estimate for compound 4 lay 1.6-fold (0.21 log units) below the measured number; measured number inside the range.
By their numbers in this assay, from the lowest: compounds 2, 1, 3 and 4 (each within the scatter of the next, the first and the last beyond it).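

Trifluoromethyl in place of fluoro gives a 1.3-fold higher number from compound 1 to compound 4 (0.12 log units; within the scatter) and 4-(trifluoromethyl)phenyl in place of 2-chlorophenyl gives a 1.1-fold higher number from compound 3 to compound 4 (0.05 log units; within the scatter) so the larger group, with 10 heavy atoms, does not separate from either compound at this position. Against bromo, the same group shows a 2.3-fold higher number from compound 2 to compound 4 (0.36 log units; beyond the scatter) as the widest gap among the four compounds, though still a modest one. On these data alone, whether an amine or a carboxylic acid on the benzyl group would shift the number further remains open. Nothing shown explains these numbers.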